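The source may report more compounds than this note shows. Statements on the series, on what has been measured and on what is new or still open speak of the compounds shown alone.

Working notes on a series built on one shared core, with compound 1 `c1ccc(Cn2ccc3nc(-c4ccccc4)nc-3c2)cc1`, compound 2 `Cc1ccc(Cn2ccc3nc(-c4ccccc4)nc-3c2)cc1` and compound 3 `Fc1cccc(Cn2ccc3nc(-c4ccccc4)nc-3c2)c1` measured so far. In an ADME assay on MDBK cells (Bos taurus) for cytotoxicity (a lower number here means that less compound is tolerated, a higher number that more compound is tolerated), compound 1 gives > 100000 nM, which is a limit and not a number. Compound 2 gives > 100000 nM, again a limit. Compound 3 gives > 100000 nM, also a limit, so compound 3 has no number of its own. Its standing is therefore (the limit of > 100000 nM in this assay, at which 3 of the 3 values shown sit).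

The next step leads to compound 4 `FC(F)(F)c1cccc(Cn2ccc3nc(-c4ccccc4)nc-3c2)c1`, with this difference: trifluoromethyl in place of fluoro on an aromatic carbon. In words, trifluoromethyl comes in place of fluoro on an aromatic carbon.

The closest measured change is a step that the two limits leave unreadable from compound 1 to compound 3, where fluoro replaces hydrogen. Next comes a step that the two limits leave unreadable from compound 1 to compound 2, where methyl replaces hydrogen, and the comparison of the two substituted compounds is a step that the two limits leave unreadable from compound 2 to compound 3. None of these has a readable size, and none of the three compounds has left the limit.

No step beyond the scatter is therefore expected in this assay, and no direction can be given. The expected change is a number no higher from compound 3 to compound 4 (the limit leaves the size open). A further report of only a limit is the likeliest outcome. For compound 4 the estimated value is 100000 nM, with an expected range from 40000 nM to 200000 nM.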

Compound 4, half-maximal cytotoxic concentration: 98000 nM
The estimate for compound 4 lay 1.0-fold (0.01 log units) above the measured number; the measured number falls inside the stated range.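

In this assay compound 4 gives 98000 nM, which is a measured number. Compound 1, compound 2 and compound 3 each remain reported as a limit: the limit of > 100000 nM in this assay, at which 3 of the 4 values shown sit.

Trifluoromethyl in place of fluoro, on an aromatic carbon meta to a large group, gives an at least 1.0-fold lower number from compound 3 to compound 4 (0.00 log units; that floor lies within the scatter), and trifluoromethyl in place of hydrogen gives an at least 1.0-fold lower number from compound 1 to compound 4 (0.00 log units; that floor lies within the scatter). Compound 4 thus adds a measured reference point at this position, with four heavy atoms entering where fluoro brought one, but neither step is shown to exceed the scatter, and the steps among compound 1, compound 2 and compound 3 cannot be read.

As far as these compounds go, the true size of either step of compound 4 stays open, since the values of compound 1 and compound 3 are limits, so the data do not show whether trifluoromethyl lowers the number at all. Also open, from the compounds shown here alone, is how this assay would respond to an amine or a carboxylic acid at the same position, or to a longer chain in place of the saturated chain carbon bound to the aromatic nitrogen.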